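The compounds below may be only part of what the source reports. "The series", "measured", "known", "first", "only" and "open" are said of these compounds alone.

Measured so far in a functional assay on PC-3 cells (Homo sapiens) for inhibition, read by MTT assay, with a stated time of 72 h; a higher number here means a weaker inhibitor, a lower number a stronger inhibitor:
- compound 1, `CCc1cccc(NC(=O)CSc2nc(Nc3ccccc3)c3ccccc3n2)c1`: 11000 nM
- compound 2, `O=C(CSc1nc(Nc2ccccc2)c2ccccc2n1)Nc1ccc(Cl)cc1`: 12900 nM

Compound 2 holds the higher of the two numbers in this assay, but its nearest neighbour is compound 1, and the step of a 1.2-fold higher number from compound 1 to compound 2 (0.07 log units; within the scatter) is too small to count as a real difference. Compound 3, `CCc1ccc(NC(=O)CSc2nc(Nc3ccccc3)c3ccccc3n2)cc1`, differs from compound 2 in a single place: ethyl in place of chloro on an aromatic carbon. Among the compounds with values here, the one measured step that bears on this, from compound 1 to compound 2, also changed only the group on the amide-type nitrogen, and it stayed within the scatter. Within the data shown here, with that as the sole guide, the step from compound 2 to compound 3 is expected to be a 1.2-fold lower number from compound 2 to compound 3 (0.07 log units; within the scatter), that is, no change beyond the scatter in either direction. Compound 3 is therefore estimated at 11000 nM in this assay, with a likely range from 5000 nM to 25000 nM.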

Compound 3, half-maximal inhibitory concentration: 17900 nM
Compound 3: middle estimate off by 1.6-fold (0.21 log units), on the low side; low and high end bracket the measured number.
By their numbers in this assay, from the lowest: compounds 1, 2 and 3 (each within the scatter of the next).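

In this assay, putting ethyl in place of chloro on this aromatic carbon gives a 1.4-fold higher number from compound 2 to compound 3 (0.14 log units; within the scatter) and so does not separate the two groups. Within the data shown here, compound 3 also allows the first comparison of the same ethyl group at two places, as 4-ethylphenyl in place of 3-ethylphenyl gives a 1.6-fold higher number from compound 1 to compound 3 (0.21 log units; within the scatter) and this shift cannot be told from repeat-measurement noise either. Nothing measured here offers an explanation for how little these changes matter.

As far as these compounds go, what an amine or a carboxylic acid at this place on the aromatic ring would do remains open. So does whether any change to the shared core, rather than to this aromatic ring, would move the number beyond the scatter.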